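Pyridin-2-yl in place of 4-fluorophenyl: what to expect

This account rests on a few compounds, and the source may have more. Where it says the series, first, only, none or still open, it means among the compounds named here.

Measured compounds:
compound 1, `O=C(Nc1cc2cc[nH]c(=O)c2cc1Cl)C1CNCC1c1ccc(F)cc1`, 9 nM
compound 2, `NCC(=O)Nc1cc2cc[nH]c(=O)c2cc1Cl`, 120 nM

In an assay on isolated protein for inhibition of Rho-associated protein kinase 2 (Homo sapiens), read by a luciferase reporter (on this read-out lower numbers stand for stronger inhibition and higher numbers for weaker inhibition), compound 1 gives 9 nM, the lowest of the two numbers. Compound 2 gives 120 nM, a higher number that lies beyond the scatter. Compound 3, `O=C(Nc1cc2cc[nH]c(=O)c2cc1Cl)C1CNCC1c1ccccn1`, differs from compound 1 by pyridin-2-yl in place of 4-fluorophenyl on a saturated ring carbon. No step of this kind has been measured among these compounds, so the expectation rests on compound 1 alone. The step of a 1.7-fold higher number from compound 1 to compound 3 (0.22 log units; within the scatter) is expected to be small, at most a little toward weaker inhibition and possibly within the scatter. Compound 3 is therefore estimated at 15 nM, in the range 4 nM to 60 nM.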

Compound 3, half-maximal inhibitory concentration: 14 nM
Estimate against measurement, compound 3: 1.1-fold (0.03 log units) above; the measured number falls inside the stated range.
By their numbers in this assay, from the lowest: compounds 1 and 3 (each within the scatter of the next); then compound 2.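

In this assay, pyridin-2-yl in place of 4-fluorophenyl on the saturated ring carbon gives a 1.6-fold higher number from compound 1 to compound 3 (0.19 log units; within the scatter). This position therefore accepts an aromatic ring with a hetero atom and a hydrogen-bond acceptor as well as one of carbon only, with the two values staying within the scatter of each other, which compound 1 alone could not show. Nothing available explains why the two groups read alike.

The compounds shown leave open how pyridin-3-yl or pyridin-4-yl would read here. They also leave open whether a carboxylic acid, an amine or a longer chain on this carbon would be accepted.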